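The source may report more compounds than this note shows. Statements on the series, on what has been measured and on what is new or still open speak of the compounds shown alone.

Three compounds built on a shared core have been run in a functional assay on HT-29 cells (Homo sapiens) for inhibition, read by MTT assay, with a stated time of 72 h; on this read-out higher numbers stand for weaker inhibition and lower numbers for stronger inhibition. Among the measured compounds shown here, compound 1 `COc1cc2c(Oc3ccc(NC(=O)c4nn(-c5ccccc5C)c(=O)cc4C)cc3F)ccnc2cc1OCCCN1CCC(C)CC1` gives 2810 nM in this assay, and compound 2 `COc1cc2c(Oc3ccc(NC(=O)c4nn(-c5cccc(F)c5)c(=O)cc4C)cc3F)ccnc2cc1OCCCN1CCC(C)CC1` gives 300 nM; the change a 9.4-fold lower number from compound 1 to compound 2 (0.97 log units; beyond the scatter) is the only single-point step among the measured pairs. Compound 3 `COc1ccc(-n2nc(C(=O)Nc3ccc(Oc4ccnc5cc(OCCCN6CCCCC6)c(OC)cc45)c(F)c3)c(C)cc2=O)cc1` gives 3200 nM in this assay, the highest of the three numbers: it lies within the scatter of compound 1 and beyond the scatter from compound 2.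

Compound 4 `COc1ccc(-n2nc(C(=O)Nc3ccc(Oc4ccnc5cc(OCCCN6CCC(C)CC6)c(OC)cc45)c(F)c3)c(C)cc2=O)cc1` differs from compound 3 by methyl in place of hydrogen on a saturated ring carbon, so that piperidin-1-yl becomes 4-methylpiperidin-1-yl. For the measured compounds named here, no measured step bears directly on this place: compound 1 and compound 2 both already carry the 4-methylpiperidin-1-yl group, and the one measured step alters a different part of the molecule. The only indirect hint is that compound 3 and compound 1, which differ in more than one place, give values within the scatter of each other. On this basis no step beyond the scatter is expected in this assay, a 1.1-fold lower number from compound 3 to compound 4 (0.03 log units; within the scatter). Compound 4 is therefore estimated at 3000 nM, with a range from 1000 nM to 9000 nM.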

Compound 4, half-maximal inhibitory concentration: 5450 nM
Estimate against measurement, compound 4: 1.8-fold (0.26 log units) below, and the stated range covers the measured number.
By their numbers in this assay, from the lowest: compound 2; then compounds 1, 3 and 4 (each within the scatter of the next).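

In this assay, adding methyl on a saturated ring carbon, which turns piperidin-1-yl into 4-methylpiperidin-1-yl, gives a 1.7-fold higher number from compound 3 to compound 4 (0.23 log units; within the scatter) and so leaves the number within the scatter at this position. With 4-methylpiperidin-1-yl held constant, the group on the aromatic nitrogen can now be compared across three compounds: 4-methoxyphenyl in place of 3-fluorophenyl gives an 18-fold higher number from compound 2 to compound 4 (1.26 log units; beyond the scatter) while 4-methoxyphenyl in place of 2-methylphenyl gives a 1.9-fold higher number from compound 1 to compound 4 (0.29 log units; within the scatter) and this leaves compound 2, with its 3-fluorophenyl group, as the one of these three set apart from the other two. Nothing shown here accounts for either the small step at the saturated ring or the large one at the aromatic nitrogen.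

The compounds shown leave open whether a hydroxyl, an amine or a longer chain on that saturated ring carbon would also stay within the scatter of compound 3. They also leave open whether the lower number seen with 3-fluorophenyl would hold with piperidin-1-yl in place of 4-methylpiperidin-1-yl, and how an unsubstituted phenyl or a 3-chlorophenyl group on the aromatic nitrogen would read.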